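Carbamoyl in place of trifluoromethoxy: expectation for compound 3

The compounds below may be only part of what the source reports. "The series", "measured", "known", "first", "only" and "open" are said of these compounds alone.

Within the data shown here, compound 2 `NC/C=C(/F)COc1ccc(OC(F)(F)F)cc1` gives 180 nM in an assay on isolated protein for inhibition of Amine oxidase [copper-containing] 3 (Homo sapiens), read by Amplex Red (a higher number here means a weaker inhibitor, a lower number a stronger inhibitor), the lowest of the two numbers so far, while compound 1 `CC(C)(C)c1ccc(OC/C(F)=C\CN)cc1` gives 210 nM, within the scatter of it. Compound 3 `NC/C=C(/F)COc1ccc(C(N)=O)cc1` differs from compound 2 by carbamoyl in place of trifluoromethoxy on an aromatic carbon. Among the measured compounds shown here, no measured step covers this exchange; the only step at that aromatic carbon, a 1.2-fold lower number from compound 1 to compound 2 (0.07 log units; within the scatter), stayed within the scatter. A modest shift in this assay is therefore expected, direction uncertain, leaning to a higher number. For compound 3 the estimate is 350 nM, range 100 nM to 1300 nM, an expected step of a 1.9-fold higher number from compound 2 to compound 3 (0.29 log units; within the scatter).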

Compound 3, half-maximal inhibitory concentration: 1070 nM
Beside the measured number, compound 3's estimate is 3.1-fold (0.49 log units) below it; measured number inside the range.
By their numbers in this assay, from the lowest: compounds 2 and 1 (each within the scatter of the next); then compound 3.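

In this assay this aromatic carbon proves sensitive to the group it carries, which the tert-butyl and trifluoromethoxy pair did not show. Carbamoyl gives a 5.9-fold higher number from compound 2 to compound 3 (0.77 log units; beyond the scatter) and a 5.1-fold higher number from compound 1 to compound 3 (0.71 log units; beyond the scatter) while those two groups remain within the scatter of each other. No measurement at hand bears on the reason for this rise. Still open, as far as these compounds go, is whether the hydrogen-bond donor that enters with carbamoyl goes with the higher number. Also open, from the compounds shown here alone, is whether a nitrile, a carboxylic acid or an amine on this aromatic carbon would track carbamoyl or the other two groups.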